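The compounds below may be only part of what the source reports. "The series", "measured", "known", "first", "only" and "open" are said of these compounds alone.

Measured compounds:
- compound 1 `CCOC(=O)CN(C)C(=O)c1ccc(C(CC)(CC)c2ccc(OCC(O)C(C)(C)C)c(C)c2)n1CC`, in an assay on HL-60 cells for agonist activity at vitamin D3 receptor (Homo sapiens), read by microscopy, with a stated time of 96 h (on this read-out lower numbers stand for an effect already at smaller amounts and higher numbers for an effect only at larger amounts of compound), compound 1 gives 210 nM
- compound 2 `C#CCNC(=O)c1ccc(C(CC)(CC)c2ccc(OCC(O)C(C)(C)C)c(C)c2)n1CC`, in this assay compound 2 gives 240 nM

Compound 2 carries the highest of the two numbers in this assay, its nearest neighbour being compound 1; the gap between them lies within the scatter, so no order between the two can be claimed. Among the compounds with values here, the single measured step, a 1.1-fold higher number from compound 1 to compound 2 (0.06 log units; within the scatter), exchanges the substituent on the carbonyl carbon of the amide and leaves the remainder of the shared core untouched.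

Compound 3 `C=CCN(C)C(=O)c1ccc(C(CC)(CC)c2ccc(OCC(O)C(C)(C)C)c(C)c2)n1CC` differs from compound 2 at the same position: allyl(methyl)amino in place of propargylamino on a carbonyl carbon. Within the data shown here, the only step that bears on this change is the one from compound 1 to compound 2, which also reworks the nitrogen substituent of this amide and stays within the scatter. Among the measured compounds shown here, the series therefore gives no sign that the amide substituent moves the number in this assay; at the same time, no measured step describes the loss of the hydrogen-bond donor together with entry of an allyl group, so the expectation rests on one comparison only. The expected step of a 1.0-fold lower number from compound 2 to compound 3 (0.02 log units; within the scatter) is none beyond the scatter. For compound 3 the estimate in this assay is 230 nM, with a range from 100 nM to 520 nM.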

Compound 3, half-maximal effective concentration: 3950 nM
Compound 3: the middle estimate sits 17-fold (1.23 log units) below what was measured; measured number above the stated range.
By their numbers in this assay, from the lowest: compounds 1 and 2 (each within the scatter of the next); then compound 3.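

The amide substituent is not a neutral position after all: in this assay, allyl(methyl)amino in place of propargylamino on a carbonyl carbon gives a 16-fold higher number from compound 2 to compound 3 (1.22 log units; beyond the scatter), and vinyl in place of ethoxycarbonyl on a saturated chain carbon bound to an amide-type nitrogen gives a 19-fold higher number from compound 1 to compound 3 (1.27 log units; beyond the scatter). Loss of the amide hydrogen does not track this shift on its own, since compound 1 also has a methyl group on the amide nitrogen and no amide hydrogen, yet stands within the scatter of compound 2; among the tertiary amides, compound 1 and compound 3 differ only at the end of the chain on that nitrogen. No measurement at hand gives a reason for the shift.

As far as these compounds go, it remains open whether the number for compound 3 follows from the double bond of the allyl group or from the absence of the ester, which a saturated propyl chain in place of allyl would help to separate. Equally open, from the compounds shown here alone, is how far the number depends on the ester itself, a question that a carboxylic acid or a primary alcohol at the end of that chain would address.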